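Series notes: pyridazinyl swap on the piperazine of compound 1

The source may report more compounds than this note shows. Statements on the series, on what has been measured and on what is new or still open speak of the compounds shown alone.

Compound 1 `CC1(C)[C@@H]2CC[C@@]1(CS(=O)(=O)N1CCN(c3cc(C(F)(F)F)ccn3)CC1)C(=O)C2` is the weaker of the two numbered results: in a functional assay on CHO-K1 cells for antagonist activity at C-X-C chemokine receptor type 3 (Homo sapiens), read by FLIPR and calcium flux (a higher number here means a weaker inhibitor, a lower number a stronger inhibitor), compound 1 gives 25100 nM. Among the compounds with values here, compound 3 `C[C@H]1CN(S(=O)(=O)C[C@]23CC[C@H](CC2=O)C3(C)C)CCN1c1ccc(C(F)(F)F)cn1` gives 158 nM in this assay, a lower number than compound 1 by a gap well beyond the scatter; the two differ in more than one place, so no single step is read from them. Compound 2 `CC1(C)[C@@H]2CC[C@@]1(CS(=O)(=O)N1C[C@@H]3C[C@H]1CN3c1ccc(C(F)(F)F)cn1)C(=O)C2` gives only a limit, > 31600 nM in this assay, which is the limit of > 31600 nM in this assay, at which 1 of the 3 values shown sits.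

Compound 4 `CC1(C)[C@@H]2CC[C@@]1(CS(=O)(=O)N1CCN(c3ccc(C(F)(F)F)nn3)CC1)C(=O)C2` keeps the shared core and the piperazine of compound 1 and differs in one place: 6-(trifluoromethyl)pyridazin-3-yl in place of 4-(trifluoromethyl)pyridin-2-yl on an amine nitrogen in a ring. Within the data shown here, no measured pair in the set differs in this way, so the size of the step is an open guess. With compound 1 already at 25100 nM, the expectation is a small step, if any, toward a higher number. The step from compound 1 to compound 4 is estimated as a 1.1-fold higher number from compound 1 to compound 4 (0.05 log units; within the scatter). Compound 4 is therefore expected near 28000 nM in this assay, in a range from 8000 nM to 100000 nM.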

Compound 4, half-maximal inhibitory concentration: 5010 nM
Estimate against measurement, compound 4: 5.6-fold (0.75 log units) above, and the stated range ends above it.
By their numbers in this assay, from the lowest: compound 3; then compound 4; then compound 1. At a limit, above all of these: compound 2.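

In this assay, within the data shown here, 6-(trifluoromethyl)pyridazin-3-yl in place of 4-(trifluoromethyl)pyridin-2-yl gives a 5.0-fold lower number from compound 1 to compound 4 (0.70 log units; beyond the scatter) and supplies the first single-place step. The earlier compounds shown here all differ in more than one place, so they could not isolate the group on this amine nitrogen in a ring. With the shared core and the six-membered non-aromatic ring with 2 nitrogen held fixed, this position responds to the aromatic ring it carries, and a change of one ring atom together with the placing of the trifluoromethyl is enough to move the number beyond the scatter.

Going by these compounds, whether the same swap carries over to the ring of compound 3, and whether a nitrile in place of the trifluoromethyl on the 6-(trifluoromethyl)pyridazin-3-yl ring holds the number, stays open. Nothing shown bears on the cause of this step.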